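Spiro-hydantoin amides: sulfonamide replacement for the piperidine amide

The source may hold more compounds than are shown below. What is called first, only, known or untested is meant among the compounds shown, and "the series" means these compounds.

Measured compounds in an assay on HEK293 cells for displacement of a labelled ligand from NPC1-like intracellular cholesterol transporter 1 (Homo sapiens); on this read-out lower numbers stand for stronger inhibition and higher numbers for weaker inhibition:
compound 1 `CC(C)(C)OC(=O)NCCCCNC(=O)CN1CN(c2ccccc2)C2(CCN(C(=O)c3ccc(C(C)(C)C)cc3)CC2)C1=O`, "not determined" (no result reported)
compound 2 `CC(C)(C)c1ccc(C(=O)N2CCC3(CC2)C(=O)N(CC(=O)NCCN)CN3c2ccccc2)cc1`, 7000 nM
compound 3 `CC1CCCN(C(=O)CN2CN(c3ccccc3)C3(CCN(C(=O)c4ccc(C(C)(C)C)cc4)CC3)C2=O)C1`, 12000 nM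

Compound 3 gives the highest number of the two with a result; its nearest neighbour is compound 2, and the step of a 1.7-fold higher number from compound 2 to compound 3 (0.23 log units; within the scatter) lies within the scatter. Compound 4 `CC(C)(C)c1ccc(C(=O)N2CCC3(CC2)C(=O)N(CC(=O)NCNS(C)(=O)=O)CN3c2ccccc2)cc1`, yet to be measured, differs from compound 3 by ((methanesulfonamido)methyl)amino in place of 3-methylpiperidin-1-yl on a carbonyl carbon. For the measured compounds named here, the only step that bears on this change is the one from compound 2 to compound 3, which swapped the same carbonyl substituent and stayed within the scatter. A change of similar size is therefore expected here, with a 1.3-fold lower number from compound 3 to compound 4 (0.12 log units; within the scatter) as the estimated step and no direction expected beyond the scatter. Compound 4 is expected at 9000 nM, within a range of 3000 nM to 27000 nM.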

Compound 4, half-maximal inhibitory concentration: 3200 nM
Compound 4: the middle estimate sits 2.8-fold (0.45 log units) above what was measured; measured number inside the range.
By their numbers in this assay, from the lowest: compound 4; then compounds 2 and 3 (each within the scatter of the next).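

For the compounds shown here, on the carbonyl carbon, ((methanesulfonamido)methyl)amino in place of 3-methylpiperidin-1-yl gives a 3.8-fold lower number from compound 3 to compound 4 (0.57 log units; beyond the scatter), the first step at this position to lie beyond the scatter. Methanesulfonamido in place of aminomethyl on the saturated chain carbon bound to an amide-type nitrogen gives a 2.2-fold lower number from compound 2 to compound 4 (0.34 log units; beyond the scatter), so the group at the end of the chain also changes the read-out. No evidence on hand explains either step.

Still open, on these data alone, is whether a longer chain carrying the methanesulfonamido group, or a carboxylic acid at the chain end, would go lower still.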